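The source may report more compounds than this note shows. Statements on the series, on what has been measured and on what is new or still open speak of the compounds shown alone.

In an ADME assay on MT4 cells (Homo sapiens) for cytotoxicity, read by MTT assay (on this read-out higher numbers stand for lower toxicity in this test and lower numbers for higher toxicity in this test), compound 3 `O=C1c2ccccc2C(Cc2ccccc2)C(=O)N1O` gives 95000 nM and compound 2 `CC(C)C1C(=O)N(O)C(=O)c2ccccc21` gives 123000 nM, two values within the usual scatter of each other. Compound 1 `Cc1ccc(CC2C(=O)N(O)C(=O)c3ccccc32)cc1` gives 5500 nM, far under both. Compound 4 `CCCCCC1C(=O)N(O)C(=O)c2ccccc21` has yet to be measured. It differs from compound 3 by butyl in place of phenyl on a saturated chain carbon bound to a saturated ring carbon and so gives up the aromatic ring of that side group.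

Among the measured compounds shown here, only one measured step bears on this, and only indirectly. The change of hydrogen in place of methyl on an aromatic carbon is a 17-fold higher number from compound 1 to compound 3 (1.24 log units; beyond the scatter), which shows that a small edit to this side group can move the number a long way. That step does not touch the phenyl itself, though. Compound 2, which has no aromatic ring in its side group, reads 123000 nM and stays level with compound 3. Together these suggest a modest step to a lower number in this assay, with real doubt about its size. The expected step is a 2.4-fold lower number from compound 3 to compound 4 (0.38 log units; beyond the scatter) and no more than that is assumed. Compound 4 is estimated at 40000 nM, within an expected range of 12000 nM to 120000 nM.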

Compound 4, half-maximal cytotoxic concentration: 98300 nM
Estimate against measurement, compound 4: 2.5-fold (0.39 log units) below, and the stated range covers the measured number.
By their numbers in this assay, from the lowest: compound 1; then compounds 3, 4 and 2 (each within the scatter of the next).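

In this assay (this assay), the aromatic ring of the side group turns out not to be needed to hold the number at this level: butyl in place of phenyl on a saturated chain carbon bound to a saturated ring carbon gives a 1.0-fold higher number from compound 3 to compound 4 (0.01 log units; within the scatter) and leaves the two compounds within the scatter of each other. The chain compounds also agree with one another, as pentyl in place of isopropyl on a saturated ring carbon gives a 1.3-fold lower number from compound 2 to compound 4 (0.10 log units; within the scatter), so neither the form of the saturated side group nor the presence of phenyl separates compound 2, compound 3 and compound 4. Compound 1 alone stands apart, with butyl in place of 4-methylphenyl giving an 18-fold higher number from compound 1 to compound 4 (1.25 log units; beyond the scatter), so among these four compounds the low number goes with the 4-methylphenyl group and not with an aromatic ring as such, given that compound 3 carries phenyl.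

No measurement shown here accounts for what the methyl on that ring does. As far as these compounds go, whether a chlorine or a methoxy group in place of that methyl would also bring the number down stays open, as does what a longer chain or a chain ending in an amine or a carboxylic acid would give.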